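The compounds below may be only part of what the source reports. "The series", "measured", "known", "first", "only" and "open" are said of these compounds alone.

Measured compounds:
compound 1, `Cc1cc(C)cc(S(=O)(=O)c2c(C(=O)NC3CC4(CCN(C(=O)OC(C)(C)C)C4)C3)[nH]c3ccc(Cl)cc23)c1`: 171000 nM in a toxicity assay on MT4 cells (Homo sapiens) for cytotoxicity, read by MTT assay, with a stated time of 7 days; on this read-out lower numbers stand for higher toxicity in this test and higher numbers for lower toxicity in this test
compound 2, `Cc1cc(C)cc(S(=O)(=O)c2c(C(=O)NC3CC4(CCN(S(C)(=O)=O)C4)C3)[nH]c3ccc(Cl)cc23)c1`: 205000 nM in this assay
compound 3, `Cc1cc(C)cc(S(=O)(=O)c2c(C(=O)NC3CC4(CCN(C(=O)OC(C)(C)C)CC4)C3)[nH]c3ccc(Cl)cc23)c1`: 133000 nM in this assay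

Compound 2 differs from compound 1 by methylsulfonyl in place of tert-butoxycarbonyl on an amine nitrogen in a ring, and this change gave a 1.2-fold higher number from compound 1 to compound 2 (0.08 log units; within the scatter). Compound 4, `Cc1cc(C)cc(S(=O)(=O)c2c(C(=O)NC3CC4(CCN(S(C)(=O)=O)CC4)C3)[nH]c3ccc(Cl)cc23)c1`, differs from compound 3 by methylsulfonyl in place of tert-butoxycarbonyl on an amine nitrogen in a ring. The difference between the core of compound 1 and the core of compound 3 is not broken down here. The two changes are the same kind of change rather than the same: in one the amine nitrogen sits in a five-membered non-aromatic ring with two ring bonds from the shared atom, in the other in a six-membered non-aromatic ring with three ring bonds from the shared atom. For compound 4 the expected step is a 1.2-fold higher number from compound 3 to compound 4 (0.08 log units; within the scatter), a small one, because a 1.2-fold higher number from compound 1 to compound 2 (0.08 log units; within the scatter) stayed within the scatter. Compound 4 is therefore estimated at 160000 nM, between 80000 nM and 320000 nM.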

Compound 4, half-maximal cytotoxic concentration: > 221000 nM
Compound 4: only a limit was reported; the forecaster's own chance of this, stated with the estimate: 20%; middle value at least 1.3-fold (0.14 log units) from the limit.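

In this assay compound 4 gives > 221000 nM, which is a limit of the assay and not a number. Putting methylsulfonyl in place of tert-butoxycarbonyl on this second core gives an at least 1.6-fold higher number from compound 3 to compound 4 (0.22 log units; that floor lies within the scatter), a floor that shows the direction of the step but not its full size. The comparison across the two cores therefore shows that the step on the second core is not a lower number, but it does not show whether the change carries over with the same size: the same change on two cores in this assay, a 1.2-fold higher number (0.08 log units; within the scatter) from compound 1 to compound 2 and an at least 1.6-fold higher number (0.22 log units; that floor lies within the scatter) from compound 3 to compound 4; the limit leaves it open whether they differ.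

The compounds shown leave open what other groups on the amine nitrogen in a ring, such as acetyl or methyl, would give in this assay. As far as these compounds go, a free amine at that nitrogen also remains open.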